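Working notes: from compound 3 to compound 4

A few compounds are considered here, and "the series" means these few. Any claim that something is new, unique, unknown or untested is made for them only; others in the source may bear on it.

Values in a functional assay on HepG2 cells (Homo sapiens) for antiproliferative activity, read by MTT assay, with a stated time of 48 h (a higher number here means a weaker inhibitor, a lower number a stronger inhibitor), for the measured compounds
compound 1 `CCN1C(=O)C(=O)c2cc(-c3ccc(OC)cc3)ccc21` gives 4470 nM
compound 2 `C=CCN1C(=O)C(=O)c2cc(-c3ccc(OC)cc3)ccc21` gives 7090 nM
compound 3 `COc1ccc(-c2ccc3c(c2)C(=O)C(=O)N3c2ccc(OC)cc2)cc1` gives > 10000 nM

Compound 3 stands at > 10000 nM as a limit of the assay, not a number. Compound 4 `COc1ccc(-c2ccc3c(c2)C(=O)C(=O)N3Cc2ccc(Cl)cc2)cc1` carries 4-chlorobenzyl in place of 4-methoxyphenyl on an amide-type nitrogen in a ring, with the count 4-chlorobenzyl in place of 4-methoxyphenyl on an amide-type nitrogen in a ring as the whole difference. The two steps bearing on this are an at least 2.2-fold higher number from compound 1 to compound 3 (0.34 log units; beyond the scatter) and an at least 1.4-fold higher number from compound 2 to compound 3 (0.14 log units; that floor lies within the scatter) as the measured changes to 4-methoxyphenyl on that nitrogen. Among the measured compounds shown here, no measured compound carries 4-chlorobenzyl, so only a modest step to a lower number is expected in this assay here. Compound 4 is estimated at 4000 nM with a lower end of 1300 nM and an upper end of 10000 nM expected. The estimate means an at least 2.5-fold lower number from compound 3 to compound 4 (0.39 log units; beyond the scatter) as the expected step.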

Compound 4, half-maximal inhibitory concentration: 250 nM
Compound 4: middle estimate off by 16-fold (1.20 log units), on the high side; measured number outside the range, below it.
By their numbers in this assay, from the lowest: compound 4; then compounds 1 and 2 (each within the scatter of the next). At a limit, above all of these: compound 3.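

In this assay, 4-chlorobenzyl on the amide-type nitrogen in a ring gives large steps (an 18-fold lower number from compound 1 to compound 4 (1.25 log units; beyond the scatter); a 28-fold lower number from compound 2 to compound 4 (1.45 log units; beyond the scatter)), whereas ethyl to allyl there stayed within the scatter. Compound 3 is held at a limit and not a number, so its step (an at least 40-fold lower number from compound 3 to compound 4 (1.60 log units; beyond the scatter)) is only a floor: the limit of > 10000 nM in this assay, at which 1 of the 4 values shown sits.

As far as these compounds go, whether the drop belongs to the chlorine or to the benzyl carbon link stays open. Unsubstituted benzyl, 4-fluorobenzyl and 4-methoxybenzyl on that nitrogen would separate the two.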